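This account rests on a few compounds, and the source may have more. Where it says the series, first, only, none or still open, it means among the compounds named here.

Working notes on the series. Compound 1 `O=C(Nc1cccc2[nH]ncc12)NC1CCc2c1cccc2N1CCCCC1` and compound 2 `O=C(Nc1cccc2[nH]ncc12)NC1CCc2cc(Cl)ccc21` share the same core and the same urea link. In an assay on isolated protein for inhibition of transient receptor potential cation channel subfamily V member 1 (Homo sapiens), read by calcium flux (on this read-out lower numbers stand for stronger inhibition and higher numbers for weaker inhibition), compound 1 gives 10 nM; in this assay compound 2 gives 10 nM, which is level with compound 1 within the scatter. Compound 3 `O=C(Nc1cccc2[nH]ncc12)NC1CCc2ccccc21` is compound 2 with hydrogen in place of chloro on an aromatic carbon. Within the data shown here, no measured pair in this set shows the effect of removing a chloro, so the step from compound 2 to compound 3 is expected to be small, if anything toward weaker inhibition, a 2.5-fold higher number from compound 2 to compound 3 (0.40 log units; beyond the scatter). Compound 3 is estimated at 25 nM, in the range 8 nM to 80 nM.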

Compound 3, half-maximal inhibitory concentration: 151 nM
Compound 3: middle estimate off by 6.0-fold (0.78 log units), on the low side; measured number outside the range, above it.
By their numbers in this assay, from the lowest: compounds 1 and 2 (each within the scatter of the next); then compound 3.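

In this assay, hydrogen in place of chloro gives a 15-fold higher number from compound 2 to compound 3 (1.18 log units; beyond the scatter), so this aromatic carbon is not indifferent to what it carries. Hydrogen in place of piperidin-1-yl gives a 15-fold higher number from compound 1 to compound 3 (1.18 log units; beyond the scatter), so compound 3, without either group, stands apart from two compounds that are level within the scatter. No available evidence accounts for these losses.

As far as these compounds go, it remains open whether fluoro, methyl or methoxy on this aromatic carbon would match chloro. The compounds shown also leave open how an amine or a carboxylic acid there would read.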